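The source may report more compounds than this note shows. Statements on the series, on what has been measured and on what is new or still open speak of the compounds shown alone.

Measured so far in a physicochemical assay for metabolic stability, in simulated intestinal fluid, with a stated time of 15 min, tested at 4 uM (on this read-out higher numbers stand for a more stable compound and lower numbers for a less stable compound), are two compounds:
- Compound 1 `COC[C@H](NC(=O)c1cc(OC)no1)C(=O)N[C@@H](COC)C(=O)N[C@@H](CC(C)C)C(=O)[C@@]1(C)CO1` gives 35%
- Compound 2 `COC[C@H](NC(=O)c1cc(C)on1)C(=O)N[C@@H](CC1CCCCC1)C(=O)N[C@@H](CC(C)C)C(=O)[C@@]1(C)CO1` gives 75%

Compound 2 stands higher of the two, and its gap to compound 1 lies beyond the usual scatter of repeated measurements. Among the compounds with values here, these two compounds differ in more than one place, and no pair measured so far differs in only one, which leaves no single measured step to lean on.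

Compound 3 `COC[C@H](NC(=O)c1cc(C)on1)C(=O)N[C@@H](CC#N)C(=O)N[C@@H](CC(C)C)C(=O)[C@@]1(C)CO1` comes from compound 2 by one change cyano in place of cyclohexyl on a saturated chain carbon, two bonds along the chain from an amide-type nitrogen and a carbonyl carbon with cyano in place of cyclohexyl on a saturated chain carbon, two bonds along the chain from an amide-type nitrogen and a carbonyl carbon.

In this assay, within the data shown here, compound 1, which also lacks the cyclohexyl group, gives 35% and this is the only guide available. A fall beyond the scatter is expected, with a number 25 percentage points lower from compound 2 to compound 3 (beyond the scatter) as the estimated step, though this rests on thin evidence. For compound 3 the estimated value is 50% with an expected range from 25% to 80% in this measurement.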

Compound 3, percent of the compound remaining: 100%
Compound 3: the middle estimate sits 50 percentage points below what was measured, outside the stated range (above it).
By their numbers in this assay, from the lowest: compound 1; then compound 2; then compound 3.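

This position does not need the large ring for the compound to survive. In this assay, exchanging cyclohexyl for cyano on a saturated chain carbon, two bonds along the chain from an amide-type nitrogen and a carbonyl carbon, gives a number 25 percentage points higher from compound 2 to compound 3 (beyond the scatter). The swap removes a six-membered carbon ring and brings in a small nitrile, yet compound 3 gives 100% and so leaves no measured loss on this read-out. Nothing shown here explains the rise, and this single step cannot separate the effect of losing the cyclohexyl ring from the effect of gaining the nitrile.

From the compounds shown here alone, it remains open whether a plain methyl, an amine or a carboxylic acid at this same place would also keep the number this high, and whether the nitrile itself matters or any small group would serve. Within the data shown here, it is also unknown whether the change from cyclohexylmethyl to cyanomethyl would bring a similar rise if other parts of the molecule were different, since this is the only single-change pair available.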